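Moving the Methoxy Group Around the Aryl Ring

The source may hold more compounds than are shown below. What is called first, only, known or untested is meant among the compounds shown, and "the series" means these compounds.

Compound 1 `COc1cccc(N2C(=O)COc3ccc(-c4cnc(Cl)c(NS(=O)(=O)c5ccc(F)cc5)c4)cc32)c1` carries a methoxyphenyl group on an amide-type nitrogen in a ring of its core. In a functional assay on HeLa cells (Homo sapiens) for antiproliferative activity, read by MTT assay, with a stated time of 72 h (on this read-out higher numbers stand for weaker inhibition and lower numbers for stronger inhibition), compound 1 reaches only the limit of the assay, > 40000 nM. This places compound 1 at the limit of > 40000 nM in this assay, at which 1 of the 2 values shown sits. Among the compounds with values here, the only other measured compound, compound 2 `O=C1COc2ccc(-c3cnc4ccccc4c3)cc2N1C1CCCCC1`, differs from it in several places and gives 19700 nM in this assay. Within the data shown here, no step between measured compounds connects them, so nothing is known yet about how this core answers to rearranging the methoxyphenyl. Compound 3 `COc1ccc(N2C(=O)COc3ccc(-c4cnc(Cl)c(NS(=O)(=O)c5ccc(F)cc5)c4)cc32)cc1` differs from compound 1 only in 4-methoxyphenyl in place of 3-methoxyphenyl on an amide-type nitrogen in a ring. As compound 1 sits at the limit of > 40000 nM in this assay, at which 1 of the 2 values shown sits, compound 3 is expected to stay near that limit, with a step of a number no higher from compound 1 to compound 3 (the limit leaves the size open) that is not beyond the scatter. Compound 3 is therefore estimated at 40000 nM, between 15000 nM and 100000 nM.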

Compound 3, half-maximal inhibitory concentration: 8320 nM
For compound 3 the middle estimate is 4.8-fold (0.68 log units) above the measured one, outside the stated range (below it).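

On the shared core, where the methoxy group sits on the aryl ring matters: in this assay, 4-methoxyphenyl in place of 3-methoxyphenyl gives an at least 4.8-fold lower number from compound 1 to compound 3 (0.68 log units; beyond the scatter). Within the data shown here, this is the first step read at this place on the amide-type nitrogen, and it shows that the same atoms, joined differently, are enough to carry a compound from the limit of the assay to a measured value. The value of compound 1 is a limit and not a number, so the full size of the step stays unknown: the limit of > 40000 nM in this assay, at which 1 of the 3 values shown sits.

The compounds shown leave open whether a 4-hydroxyphenyl or a 4-ethoxyphenyl at this place would follow compound 3. Equally open, going by these compounds, is whether a plain phenyl would fall nearer compound 1 or compound 3.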